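Thiourea benzamides: aryl swap on the chain carbon

This account rests on a few compounds, and the source may have more. Where it says the series, first, only, none or still open, it means among the compounds named here.

Measured so far in a functional assay on HCT-116 cells (Homo sapiens) for cytotoxicity, read by MTT assay, with a stated time of 72 h; a higher number here means a weaker inhibitor, a lower number a stronger inhibitor:
compound 1 `Nc1ccccc1NC(=O)c1ccc(NC(=S)NCc2cncc(Br)c2)cc1` — 9200 nM
compound 2 `Cc1ccc(CNC(=S)Nc2ccc(C(=O)Nc3ccccc3N)cc2)cn1` — 11000 nM
compound 3 `Nc1ccccc1NC(=O)c1ccc(Cn2cc(-c3ccc(NC(=O)NCc4cccnc4)cc3)nn2)cc1` — a limit of the assay, > 100000 nM

Compound 2 and compound 1 sit together within the scatter, a 1.2-fold higher number from compound 1 to compound 2 (0.08 log units; within the scatter), so neither can be set apart from the other. The value of compound 3 is a limit only, (the limit of > 100000 nM in this assay, at which 1 of the 3 values shown sits).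

Compound 4 `Nc1ccccc1NC(=O)c1ccc(NC(=S)NCc2cccc(F)c2)cc1` differs from compound 2 by 3-fluorophenyl in place of 6-methylpyridin-3-yl on a saturated chain carbon bound to an amide-type nitrogen. Among the measured compounds shown here, the one measured step at this place, a 1.2-fold higher number from compound 1 to compound 2 (0.08 log units; within the scatter), stayed within the scatter; no measured step here goes beyond it. A change within the scatter is therefore expected in this assay, a 1.2-fold lower number from compound 2 to compound 4 (0.09 log units; within the scatter).

Compound 4 is estimated at 9000 nM, ranging from 3500 nM to 25000 nM.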

Compound 4, half-maximal inhibitory concentration: 5900 nM
The estimate for compound 4 lay 1.5-fold (0.18 log units) above the measured number, and the stated range covers the measured number.
By their numbers in this assay, from the lowest: compounds 4, 1 and 2 (each within the scatter of the next). At a limit, above all of these: compound 3.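

Among the compounds shown here, with 3-fluorophenyl, a ring of carbon only now stands at this place, where the earlier step compared only two pyridine rings. Both new steps stay within the scatter, a 1.9-fold lower number from compound 2 to compound 4 (0.27 log units; within the scatter) and a 1.6-fold lower number from compound 1 to compound 4 (0.19 log units; within the scatter), so removing the ring nitrogen does not set compound 4 apart from compound 1 or compound 2. No measured property bears on this result.

As far as these compounds go, whether an amine or a carboxylic acid on this ring, or a longer chain at this place, would move the number beyond the scatter remains open. Compound 3, whose value is a limit, differs from these compounds in more than one place and gives no reading of this change.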